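The source may report more compounds than this note shows. Statements on the series, on what has been measured and on what is new or still open speak of the compounds shown alone.

Compound 1 `CC(C)(C)c1cn(C[C@H](O)[C@H]2OC(=O)C(OCc3ccccc3)=C2OCc2ccccc2)nn1`: 13300 nM
Compound 2 `O=C1O/C(=C\Cn2cc(-c3cccc(O)c3)nn2)C(OCc2ccccc2)=C1OCc1ccccc1`: 42600 nM

In an ADME assay on HFF cells (Homo sapiens) for cytotoxicity, read by MTT assay, with a stated time of 72 h (on this read-out higher numbers stand for weaker inhibition and lower numbers for stronger inhibition), compound 1 gives 13300 nM, the lower of the two numbers shown, while compound 2 gives 42600 nM, and that gap lies beyond the usual scatter. Compound 3 `Cc1ccc(-c2cn(C[C@H](O)[C@H]3OC(=O)C(OCc4ccccc4)=C3OCc3ccccc3)nn2)cc1` differs from compound 1 by 4-methylphenyl in place of tert-butyl on an aromatic carbon. Within the data shown here, no measured pair shows this change, so its effect rests only on expectation. In this assay the change is expected to give a small step toward a lower number, estimated as a 1.5-fold lower number from compound 1 to compound 3 (0.17 log units; within the scatter). Compound 3 is therefore expected at about 9000 nM, with a range from 3000 nM to 30000 nM.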

Compound 3, half-maximal inhibitory concentration: > 100000 nM
Compound 3: a limit, no number; the forecaster's own chance of this, stated with the estimate: 10%; middle value at least 11-fold (1.04 log units) from the limit.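

In this assay, 4-methylphenyl in place of tert-butyl on this aromatic carbon gives an at least 7.5-fold higher number from compound 1 to compound 3 (0.87 log units; beyond the scatter), so the group at this position can strongly change the read-out, and here the change goes toward weaker inhibition of the cells. Compound 3 stands at a limit, not at a number: the limit of > 100000 nM in this assay, at which 1 of the 3 values shown sits.

From the compounds shown here alone, this single pair cannot show whether the ring or its methyl goes with the step, and the full size of the step stays unknown. Going by these compounds, how a plain phenyl, an amine or a carboxylic acid on this carbon would read also remains open.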